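Swapping the Pyridinyl Ethenyl Arm for a Trifluoromethoxyphenyl Arm

The source may hold more compounds than are shown below. What is called first, only, known or untested is meant among the compounds shown, and "the series" means these compounds.

Compound 1 `COC(=O)/C=C/c1cccc(N(Cc2ccc(/C=C/c3ccccn3)cc2)C(=O)C2CCCCC2)c1`: 309 nM
Compound 2 `COC(=O)/C=C/c1cccc(N(Cc2ccc(/C=C/c3ccccn3)cc2)C(=O)C(C)C)c1`: 310 nM
Compound 3 `COC(=O)/C=C/c1cccc(N(Cc2ccc(-c3cccc(OC)c3)cc2)C(=O)NC(C)C)c1`: 1370 nM

All three were measured in an assay on isolated protein with Bile acid receptor (Homo sapiens) as the target; on this read-out higher numbers stand for an effect only at larger amounts of compound and lower numbers for an effect already at smaller amounts. Compound 2 has the second highest number of the three: its nearest neighbour is compound 1, and the step of a 1.0-fold higher number from compound 1 to compound 2 (0.00 log units; within the scatter) lies within the scatter, so the two cannot be ranked. Its furthest neighbour is compound 3, whose number is beyond the scatter from that of compound 2.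

Compound 4 `COC(=O)/C=C/c1cccc(N(Cc2ccc(-c3cccc(OC(F)(F)F)c3)cc2)C(=O)C(C)C)c1` is built from compound 2 by one change: 3-(trifluoromethoxy)phenyl in place of 2-(pyridin-2-yl)ethenyl on an aromatic carbon. Among the compounds with values here, no measured step tests this exact change. Within the data shown here, the only measured step, a 1.0-fold higher number from compound 1 to compound 2 (0.00 log units; within the scatter), alters the group on the carbonyl carbon and leaves the aromatic arm untouched, so it gives no guidance here. Compound 3 does carry a phenyl arm with an oxygen substituent rather than the pyridinyl ethenyl arm, but it also carries a urea in place of the amide, so its value cannot be attributed to either change alone. The values of compound 2 and compound 3 merely hint that a phenyl arm may go with a higher number. Compound 4 is therefore expected to show a modest rise, a 2.3-fold higher number from compound 2 to compound 4 (0.35 log units; beyond the scatter), with wide uncertainty. The estimate for compound 4 is 700 nM, expected to fall between 250 nM and 2500 nM.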

Compound 4, half-maximal effective concentration: 247 nM
The estimate for compound 4 lay 2.8-fold (0.45 log units) above the measured number; measured number outside the range, below it.
By their numbers in this assay, from the lowest: compounds 4, 1 and 2 (each within the scatter of the next); then compound 3.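

In this assay, the exchange of arms gives a 1.3-fold lower number from compound 2 to compound 4 (0.10 log units; within the scatter) and so lies within the scatter. On this aromatic carbon, para to a large group, the 2-(pyridin-2-yl)ethenyl arm with its ring nitrogen and its double bond can therefore give way to 3-(trifluoromethoxy)phenyl, a ring of carbon only with more heavy atoms, and the number stays level. No measurement shown here offers an explanation for this tolerance.

The compounds shown leave open whether the position accepts the 3-(trifluoromethoxy)phenyl arm alongside other carbonyl groups, such as the urea of compound 3, and whether the trifluoromethoxy group itself matters compared with a plain phenyl ring. They also leave open how a free carboxylic acid in place of the methyl ester, or an amine on the new phenyl ring, would read out.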